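A few compounds are considered here, and "the series" means these few. Any claim that something is new, unique, unknown or untested is made for them only; others in the source may bear on it.

Measured in an ADME assay on microsomes from liver (Mus musculus, strain CD-1) for metabolic stability, read by LC-MS, with a stated time of 1 h, tested at 50 uM, in the presence of a further agent that is not named here; a lower number here means that less of the compound is left, a higher number that more of the compound is left:
Compound 1 `O=C(NCc1cccc(Cn2cnc3ccccc32)c1)c1cc(Br)c[nH]1` gives 32%
Compound 2 `O=C(NCc1cccc(Cn2cnc3ccccc32)c1)c1cc2ccccc2[nH]1` gives 65%

Compound 2 has the higher of the two numbers, at 65%, and compound 1 lies beyond the scatter under it. Compound 3 `N#Cc1ccc(C(=O)NCc2cccc(Cn3cnc4ccccc43)c2)cc1` has not yet been measured. It differs from compound 2 at one place: 4-cyanophenyl in place of 1H-indol-2-yl on a carbonyl carbon. In words, 4-cyanophenyl stands in place of 1H-indol-2-yl on a carbonyl carbon. For the measured compounds named here, only one measured step bears on this change, a number 33 percentage points higher from compound 1 to compound 2 (beyond the scatter), a large step made on the same carbonyl carbon. Going by the values given here, it shows that the group at this place can move the number widely, but the data hold no compound that already carries 4-cyanophenyl. With compound 2 at the top of this small range, a moderate fall is the more likely direction, and the expected step is a number 15 percentage points lower from compound 2 to compound 3 (beyond the scatter). For compound 3 the estimated value in this assay is 50%, with an expected range of 25% to 75%.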

Compound 3, percent of the compound remaining: 59%
Beside the measured number, compound 3's estimate is 9 percentage points below it; measured number inside the range.
By their numbers in this assay, from the lowest: compound 1; then compounds 3 and 2 (each within the scatter of the next).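

In this assay, the step of a number 6 percentage points lower from compound 2 to compound 3 (within the scatter) shows that this place on the carbonyl carbon tolerates more than one group: 4-cyanophenyl gives up the five-membered aromatic ring and the hydrogen-bond donor of 1H-indol-2-yl, yet the number stays within the scatter. The other step, a number 27 percentage points higher from compound 1 to compound 3 (beyond the scatter), shows that the rise over 4-bromo-1H-pyrrol-2-yl is not confined to 1H-indol-2-yl. No measurement here explains either step.

The compounds leave open which feature of 4-bromo-1H-pyrrol-2-yl goes with its lower number, and whether the nitrile contributes at all. A plain phenyl, or a phenyl carrying an amine or a carboxylic acid in place of the nitrile, would test that on the same carbonyl carbon.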